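A few compounds are considered here, and "the series" means these few. Any claim that something is new, unique, unknown or untested is made for them only; others in the source may bear on it.

Measured compounds in a functional assay on U-251 cells (Homo sapiens) for inhibition, read by sulforhodamine B assay, with a stated time of 48 h; on this read-out lower numbers stand for stronger inhibition of growth and higher numbers for weaker inhibition of growth:

compound 1 `CCOC(=O)C1=C(C)NC(=S)NC1c1ccc(O)cc1` gives 27.2 ug/mL
compound 2 `CCCc1ccc(C2NC(=S)NC(C)=C2C(=O)OCC)cc1` gives 29.2 ug/mL
compound 3 `CCCc1ccc(C2NC(=O)NC(C)=C2C(=O)OCC)cc1` gives 35.4 ug/mL

Within the data shown here, the three measured values sit within the usual scatter of one another, so the series so far gives no separation between its members in this assay. Compound 1 and compound 2 share a core and differ in one place: hydroxy in place of propyl on an aromatic carbon. The step this change made is a 1.1-fold lower number from compound 2 to compound 1 (0.03 log units; within the scatter), which is a flat result.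

Compound 3 differs from compound 2 in the core; the difference between the two cores is not broken down here. What the two values show is that compound 3 and compound 2 lie within the scatter of each other.

The unmeasured compound 4 `CCOC(=O)C1=C(C)NC(=O)NC1c1ccc(O)cc1` stands to compound 3 as compound 1 stands to compound 2: hydroxy in place of propyl on an aromatic carbon. The place lines of the two changes agree word for word, so this is the same change on a different core. Since the change has been made once, and only once, the expectation rests on that single pair together with the value of compound 3.

For compound 4 the expected step in this assay is a 1.1-fold lower number from compound 3 to compound 4 (0.03 log units; within the scatter), because the matched step a 1.1-fold lower number from compound 2 to compound 1 (0.03 log units; within the scatter) was flat. Compound 4 is therefore estimated at 33 ug/mL, with an expected range from 19 ug/mL to 58 ug/mL that allows for the scatter of this kind of measurement.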

Compound 4, concentration for 50% growth inhibition: 4.2 ug/mL
Compound 4: middle estimate off by 7.9-fold (0.90 log units), on the high side; the measured number lies below the stated range.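

In this assay, hydroxy in place of propyl on an aromatic carbon now gives an 8.4-fold lower number from compound 3 to compound 4 (0.93 log units; beyond the scatter), so the step seen on the core of compound 2 does not carry over to the core of compound 3: the same change on two cores in this assay, a 1.1-fold lower number (0.03 log units; within the scatter) from compound 2 to compound 1 and an 8.4-fold lower number (0.93 log units; beyond the scatter) from compound 3 to compound 4, 7.9-fold (0.89 log units) apart, beyond the scatter of two such steps In this series the outcome of the change therefore depends on the core it is made on, flat on one core and clear on the other, and a matched step from one of these cores is a poor guide to the other. This rests on a single pair per core, and it does not show what in the two cores separates the steps, nor how the change would behave on any further core.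

Still open, going by these compounds, is whether the step on the core of compound 3 is particular to hydroxy, which a methoxy group, an amine, a carboxylic acid or a longer chain in the same place on that core could test, each set against the same group on the core of compound 2. On these data alone, with only propyl and hydroxy compared on both cores, it also remains open whether the two cores part for other groups or only for this one change.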